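Swapping an ethyl piperazine for a dimethyl one

A few compounds are considered here, and "the series" means these few. Any claim that something is new, unique, unknown or untested is made for them only; others in the source may bear on it.

Three compounds have numbers so far in an ADME assay on microsomes from liver (Rattus norvegicus) for metabolic stability, read by LC-MS, using NADPH, with stated times of 10 min and 60 min (on this read-out higher numbers stand for fast clearance and lower numbers for slow clearance), and are set out here

Compound 1 `CCN(Cc1cc(N2CCN(C)CC2)nc(C)n1)C1CCCc2cccnc21` gives 1280 mL/min/kg
Compound 2 `Cc1nc(CN(C)C2CCCc3cccnc32)c(C#N)c(N2CCN(C)CC2)n1` gives 1640 mL/min/kg
Compound 3 `CCN1CCN(c2cc(CN(C)[C@H]3CCCc4cccnc43)nc(C)n2)CC1` gives 2180 mL/min/kg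

Repeated measurements of one compound never agree exactly, so a gap between two numbers means something only when it exceeds the usual scatter. Compound 1 and compound 2 both lie within that scatter of compound 3, so no order can be read among them in this assay and the three stand as one group.

Compound 4 `Cc1nc(CN(C)[C@H]2CCCc3cccnc32)cc(N2CCN(C)[C@H](C)C2)n1` has not yet been measured. It carries 3,4-dimethylpiperazin-1-yl in place of the 4-ethylpiperazin-1-yl of compound 3 on an aromatic carbon 3,4-dimethylpiperazin-1-yl in place of 4-ethylpiperazin-1-yl on an aromatic carbon and so has the same atoms, joined differently.

Going by the values given here, no two measured compounds differ in one place only, so the data hold no direct guide to this change. The best anchors are compound 3 at 2180 mL/min/kg and the group around it. No shift beyond the scatter is expected, and the estimated move is a 1.3-fold lower number from compound 3 to compound 4 (0.11 log units; within the scatter) in this assay for now. For compound 4 the estimated clearance is 1700 mL/min/kg with 900 mL/min/kg to 3200 mL/min/kg as the expected range.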

Compound 4, clearance: > 497 mL/min/kg
Compound 4: no number, only a limit; the forecaster's own chance of this, stated with the estimate: 5%; the middle value lies beyond the limit too.
By their numbers in this assay, from the lowest: compounds 1, 2 and 3 (each within the scatter of the next).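

In this assay, going by these compounds alone, compound 4 gives > 497 mL/min/kg as a limit and not a number, so no step from compound 3 to compound 4 can be read. The compounds shown leave open whether 3,4-dimethylpiperazin-1-yl in place of 4-ethylpiperazin-1-yl on the shared core changes clearance at all, and in which direction.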